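Swapping a pyrimidine for an oxime ether on a shared core

The source may report more compounds than this note shows. Statements on the series, on what has been measured and on what is new or still open speak of the compounds shown alone.

Compound 2 `c1cnc(-c2ccccc2NCC2=NCCN2)nc1`: 81.3 nM
Compound 1 `c1ccc(-c2cnccn2)c(NCC2=NCCN2)c1`: 182 nM

In a functional assay for activation of Alpha-1D adrenergic receptor (Homo sapiens) (a lower number here means that less compound is needed, a higher number that more compound is needed for the effect), compound 2 gives 81.3 nM, the lowest of the two numbers; compound 1 gives 182 nM. Among the measured compounds shown here, the only measured step, a 2.2-fold lower number from compound 1 to compound 2 (0.35 log units; beyond the scatter), exchanges one aromatic heterocycle for another. Compound 3 `CC/C(=N/OC)c1ccccc1NCC1=NCCN1` differs from compound 2 by a group of 6 heavy atoms (4 carbon, 1 nitrogen, 1 oxygen; no ring) in place of a group of 6 heavy atoms (4 carbon, 2 nitrogen; one six-membered aromatic ring with 2 hetero atoms), on an aromatic carbon. For the measured compounds named here, no measured step exchanges a ring for a chain, so that modest step is only a rough guide. Compound 3 is therefore expected to give 150 nM in this assay, within 40 nM to 600 nM, a step of a 1.8-fold higher number from compound 2 to compound 3 (0.27 log units; within the scatter) that may not exceed the scatter.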

Compound 3, half-maximal effective concentration: < 5020 nM
Compound 3: only a limit was reported; the forecaster's own chance of this, stated with the estimate: 5%; the middle value is on the limit's open side.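

In this assay compound 3 gives < 5020 nM, which is a limit and not a number, so its steps from compound 1 and compound 2 cannot be read. The compounds shown leave open whether exchanging the pyrimidin-2-yl ring for a group with no ring changes the number at all.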